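Fluoro substitution on the aniline ring of the series

This account rests on a few compounds, and the source may have more. Where it says the series, first, only, none or still open, it means among the compounds named here.

For the measured compounds named here, compound 1 `Oc1nc2nonc2nc1Nc1cccc(F)c1` gives 31200 nM in an assay on mitochondria from L6 cells (Rattus norvegicus) for activation, with a stated time of 90 min (a lower number here means that less compound is needed, a higher number that more compound is needed for the effect), and stands highest among the three measured members. Compound 2 `CCCCCCc1ccc(Nc2nc3nonc3nc2O)cc1` gives 4700 nM in this assay, and compound 3 `CCCCCCc1ccc(Nc2nc3nonc3nc2O)c(F)c1` gives 3300 nM. The difference between the cores of compound 1 and compound 2 is not broken down here. From compound 2 to compound 3 the change is fluoro in place of hydrogen on an aromatic carbon, and it made a 1.4-fold lower number from compound 2 to compound 3 (0.15 log units; within the scatter). Compound 4 `Oc1nc2nonc2nc1Nc1cc(F)cc(F)c1` carries the same kind of change from compound 1, (fluoro in place of hydrogen on an aromatic carbon); the surroundings differ, as the fluoro now enters meta to a fluoro group and meta to a large group rather than ortho to a large group and meta to a hexyl group. A step of similar size, a 1.3-fold lower number from compound 1 to compound 4 (0.11 log units; within the scatter), is expected in this assay because the same kind of change gave a 1.4-fold lower number from compound 2 to compound 3 (0.15 log units; within the scatter). Compound 4 is therefore estimated at 24000 nM, between 10000 nM and 60000 nM.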

Compound 4, half-maximal effective concentration: 23400 nM
Beside the measured number, compound 4's estimate is 1.0-fold (0.01 log units) above it, and the stated range covers the measured number.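

In this assay the new step is a 1.3-fold lower number from compound 1 to compound 4 (0.12 log units; within the scatter), and it agrees with the earlier one: the same change on two cores in this assay, a 1.4-fold lower number (0.15 log units; within the scatter) from compound 2 to compound 3 and a 1.3-fold lower number (0.12 log units; within the scatter) from compound 1 to compound 4, 1.1-fold (0.03 log units) apart, within the scatter of two such steps The change therefore carries from one core to the other as a small step of similar size, with the fluoro entering at a different place on each. Neither step lies beyond the scatter, so the two pairs do not show that fluoro lowers the number on either core, and they set no rule for the wider series.

On these data alone, whether other groups in place of that hydrogen, such as chloro, trifluoromethyl or a nitrile, would give a step beyond the scatter remains open. Also open, as far as these compounds go, is how an amine or a carboxylic acid at that place would compare.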